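The compounds below may be only part of what the source reports. "The series", "measured", "known", "first", "only" and "open" are said of these compounds alone.

Measured in a functional assay on HeLa cells (Homo sapiens) for cytotoxicity, read by MTT assay, with a stated time of 72 h; on this read-out higher numbers stand for weaker inhibition and lower numbers for stronger inhibition:
- compound 1 `CCOC(=O)c1csc2nc(-c3ccc(NC(=O)CC)cc3)cn12`: > 20000 nM
- compound 2 `CCOC(=O)c1csc2nc(-c3ccc(NC(=O)c4ccco4)cc3)cn12`: > 20000 nM

Both entries are limits of the assay, not numbers. In this assay, compound 2 gives > 20000 nM, which is a limit. Among the compounds with values here, the same holds for its only measured neighbour, as the record shows (the limit of > 20000 nM in this assay, at which 2 of the 2 values shown sit).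

Compound 3 `CCOC(=O)c1csc2nc(-c3ccc(NC(=O)CCl)cc3)cn12` changes one group: chloromethyl in place of furan-2-yl on a carbonyl carbon. This puts chloromethyl in place of furan-2-yl on a carbonyl carbon. Within the data shown here, one measured step touches that same place, a step that the two limits leave unreadable from compound 1 to compound 2, so it offers no size to carry over. Any expectation is therefore weakly grounded, and compound 3 may well return only a limit again. A modest move towards stronger inhibition is the tentative expectation, with the expected step being an at least 1.6-fold lower number from compound 2 to compound 3 (0.22 log units; that floor lies within the scatter). For compound 3 the estimated value is 12000 nM, with an expected range of 2500 nM to 20000 nM.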

Compound 3, half-maximal inhibitory concentration: > 20000 nM
Compound 3: a limit, no number; the forecaster's own chance of this, stated with the estimate: 55%; middle value at least 1.6-fold (0.22 log units) from the limit.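

Compound 3 also returns only a limit in this assay, so no step can be read among compound 1, compound 2 and compound 3: the limit of > 20000 nM in this assay, at which 3 of the 3 values shown sit.

The compounds shown leave open whether ethyl, furan-2-yl and chloromethyl on the carbonyl carbon differ at all in this assay.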